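Cytotoxicity in Skin Cells After Adding Two Chlorines

This account rests on a few compounds, and the source may have more. Where it says the series, first, only, none or still open, it means among the compounds named here.

Three compounds were tested in an ADME assay on BJ cells (Homo sapiens) for cytotoxicity, with a stated time of 72 h; on this read-out lower numbers stand for an effect already at smaller amounts and higher numbers for an effect only at larger amounts of compound. Compound 1 `COc1ccc(/C=C/[C@@](C)(/C=C/c2ccc(O)c(/C=C/C#N)c2)CCC=C(C)C)cc1` gave only a limit of the assay there, > 23700 nM. Compound 2 `CC(C)=CCC[C@@](C)(/C=C/c1ccc(C)cc1)/C=C/c1ccc(O)cc1` also returned a limit, > 36600 nM. Compound 3 `C=C[C@@](C)(/C=C/c1ccc(Nc2ccccc2)cc1)CCC=C(C)C` likewise reached only a limit, > 36600 nM, so it stands with the other two at the edge of what this assay can report, as the limit of > 36600 nM in this assay, at which 2 of the 3 values shown sit, shows. Compound 4 `C=C[C@@](C)(/C=C/c1ccc(Nc2ccc(Cl)c(Cl)c2)cc1)CCC=C(C)C` has not yet been measured. It differs from compound 3 in one place: 3,4-dichlorophenyl in place of phenyl on a nitrogen on an aromatic ring. Among the measured compounds shown here, no step between measured compounds is available to guide the expectation. The step of an at least 1.2-fold lower number from compound 3 to compound 4 (0.08 log units; that floor lies within the scatter) is expected to be small, likely within the usual scatter, since none of the three compounds showed any effect the assay could resolve. For compound 4 the expected value is 30000 nM, with a plausible range from 8000 nM to 70000 nM, and a good chance that the assay again reports only a limit.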

Compound 4, half-maximal effective concentration: > 36600 nM
Compound 4 gave a limit, no number; the forecaster's own chance of this, stated with the estimate: 65%; middle value at least 1.2-fold (0.08 log units) from the limit.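

Among the compounds shown here, compound 3 and compound 4 both gave only a limit in this assay, so no step between them can be read. Going by these compounds, whether 3,4-dichlorophenyl in place of phenyl alters cytotoxicity at all remains open.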